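The source may hold more compounds than are shown below. What is called first, only, known or untested is meant among the compounds shown, and "the series" means these compounds.

Measured so far:
compound 1, `CCCCCc1cc(C)c(C(=O)N=C(N)N)cc1S(C)(=O)=O` — 27 nM
compound 2, `Cc1cc(-c2ccc(Cl)cc2)c(S(C)(=O)=O)cc1C(=O)N=C(N)N` — 45 nM
compound 3, `Cc1cc(SC(C)C)c(S(C)(=O)=O)cc1C(=O)N=C(N)N` — 12 nM

In a functional assay for inhibition of sodium/hydrogen exchanger (Oryctolagus cuniculus) (on this read-out lower numbers stand for stronger inhibition and higher numbers for weaker inhibition), compound 3 stands lowest of the three numbers. Its nearest neighbour is compound 1, with a 2.3-fold lower number from compound 1 to compound 3 (0.35 log units; beyond the scatter), and the furthest is compound 2, with a 3.8-fold lower number from compound 2 to compound 3 (0.57 log units; beyond the scatter). Compound 4, `Cc1cc(-n2ccnc2C)c(S(C)(=O)=O)cc1C(=O)N=C(N)N`, is the next compound to be measured; it differs from compound 3 in one place: 2-methyl-1H-imidazol-1-yl in place of isopropylsulfanyl on an aromatic carbon.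

Going by the values given here, two measured steps bear on this change, since both altered the same aromatic carbon. The step from compound 1 to compound 3 lowered the number modestly, and the step from compound 2 to compound 3 lowered it by more, while the step from compound 1 to compound 2, which brought in an aromatic ring, gave a 1.7-fold higher number from compound 1 to compound 2 (0.22 log units; within the scatter). Among the compounds with values here, no measured step brings in a five-membered aromatic ring with hetero atoms, so the direction for compound 4 is uncertain. On these numbers compound 4 is expected to land near compounds 1 and 2, with a modest rise of a 2.5-fold higher number from compound 3 to compound 4 (0.40 log units; beyond the scatter) expected, giving an estimate of 30 nM in a range from 10 nM to 90 nM for compound 4.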

Compound 4, half-maximal inhibitory concentration: 29 nM
Compound 4: middle estimate off by 1.0-fold (0.01 log units), on the high side; measured number inside the range.
By their numbers in this assay, from the lowest: compound 3; then compounds 1, 4 and 2 (each within the scatter of the next).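

In this assay, the 2-methyl-1H-imidazol-1-yl group puts a five-membered aromatic ring with 2 hetero atoms on this aromatic carbon, ortho to the methylsulfonyl group, and the change gives a 2.4-fold higher number from compound 3 to compound 4 (0.38 log units; beyond the scatter), so this ring does not match the isopropylsulfanyl group. Against the other two groups, the ring gives a 1.6-fold lower number from compound 2 to compound 4 (0.19 log units; within the scatter) and a 1.1-fold higher number from compound 1 to compound 4 (0.03 log units; within the scatter), which leaves compound 3 as the most potent of the four, with its steps to all the others beyond the scatter, while pentyl, 4-chlorophenyl and the new ring cannot be told apart. Nothing measured here accounts for the gap between compound 3 and the rest.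

The compounds shown leave open whether the sulfur atom or the isopropyl part of the isopropylsulfanyl group matters more, which a cyclopentyl or an isopropoxy group would help to separate. They also leave open what the methyl on the imidazole ring contributes, which the plain 1H-imidazol-1-yl group would test.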